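Swapping Bromo for Dimethylamino on an Aromatic Carbon

A few compounds are considered here, and "the series" means these few. Any claim that something is new, unique, unknown or untested is made for them only; others in the source may bear on it.

Compound 1 `Cc1cc(Br)c2nc(-c3nnc(-c4ccccc4)o3)cn2c1` and compound 2 `Cc1cc(Br)c2nc(-c3nnc(-c4ccc(Br)cc4)o3)cn2c1` share one core, and both were measured in a functional assay on DU-145 cells (Homo sapiens) for antiproliferative activity, read by MTT assay, with a stated time of 48 h; a higher number here means a weaker inhibitor, a lower number a stronger inhibitor. In this assay compound 1 gives 18900 nM, and compound 2 gives 22300 nM. Going by the values given here, compound 2 therefore stands level with compound 1, its only neighbour on these numbers, and the two values lie within the usual scatter of repeated measurements.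

Compound 3 `Cc1cc(Br)c2nc(-c3nnc(-c4ccc(N(C)C)cc4)o3)cn2c1` keeps the same core and differs from compound 2 in one place: dimethylamino in place of bromo on an aromatic carbon. This puts dimethylamino in place of bromo on an aromatic carbon, para to a large group.

Among the compounds with values here, only one measured step bears on this place, and it replaces hydrogen with bromo: a 1.2-fold higher number from compound 1 to compound 2 (0.07 log units; within the scatter). That step stays within the scatter. Within the data shown here, no measured compound carries dimethylamino, so this single step is a thin guide. On that evidence, no step beyond the scatter is expected in this assay, and the range is kept wide. The estimated step is a 1.2-fold lower number from compound 2 to compound 3 (0.07 log units; within the scatter). Compound 3 is expected at about 19000 nM, with an estimated range from 7000 nM to 45000 nM.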

Compound 3, half-maximal inhibitory concentration: 12800 nM
The estimate for compound 3 lay 1.5-fold (0.17 log units) above the measured number, and the stated range covers the measured number.
By their numbers in this assay, from the lowest: compounds 3, 1 and 2 (each within the scatter of the next).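

In this assay the change to dimethylamino gives a 1.7-fold lower number from compound 2 to compound 3 (0.24 log units; within the scatter) and, counted from hydrogen on the same aromatic carbon, a 1.5-fold lower number from compound 1 to compound 3 (0.17 log units; within the scatter) and both steps stay within the scatter. The earlier compounds had shown only that bromo and hydrogen could not be told apart at this place, para to a large group; compound 3 now adds a group that brings in nitrogen and a hydrogen-bond acceptor, and it still cannot be told apart from either of them. On these numbers, then, hydrogen, bromo and dimethylamino at this place make no readable difference, and nothing available here explains why these three compounds lie so close together.

Going by these compounds, three groups on one carbon are a small sample, so it remains open whether any group at this place can move the number beyond the scatter, as a carboxylic acid, a primary amine or a longer alkyl chain might. On these data alone, it also remains open whether the bromo and the methyl on the shared core matter more to this result than the group studied here, since all three compounds carry both unchanged.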